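Adding acetyl to the amine nitrogen of compound 2

A few compounds are considered here, and "the series" means these few. Any claim that something is new, unique, unknown or untested is made for them only; others in the source may bear on it.

Measured in a functional assay on MCF7 cells (Homo sapiens) for inhibition, read by MTT assay, with a stated time of 3 days; a higher number here means a weaker inhibitor, a lower number a stronger inhibitor:
Compound 1 `COc1cc(-c2nc3ccccc3s2)ccc1OCC(=O)NNC(=O)CN[C@@H](CS(=O)(=O)O)C(=O)O`: 1870 nM
Compound 2 `CCOC(=O)[C@H](CS)NCC(=O)NNC(=O)COc1ccc(-c2nc3ccccc3s2)cc1OC`: 2880 nM

Compound 2 stands level with compound 1, as the two numbers lie within the usual scatter of repeat measurements. Compound 3 `CCOC(=O)[C@H](CS)N(CC(=O)NNC(=O)COc1ccc(-c2nc3ccccc3s2)cc1OC)C(C)=O` differs from compound 2 by one change, acetyl in place of hydrogen on an amine nitrogen. Among the compounds with values here, the only measured step, a 1.5-fold higher number from compound 1 to compound 2 (0.19 log units; within the scatter), swapped a different group on that same nitrogen. It says little about adding acetyl there, so no shift beyond the scatter is expected, though the uncertainty is wide. The expected change is a 1.0-fold higher number from compound 2 to compound 3 (0.02 log units; within the scatter). The estimate for compound 3 is 3000 nM, with an expected range of 1000 nM to 9000 nM.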

Compound 3, half-maximal inhibitory concentration: 1890 nM
Compound 3: the middle estimate sits 1.6-fold (0.20 log units) above what was measured, and the stated range covers the measured number.
By their numbers in this assay, from the lowest: compounds 1, 3 and 2 (each within the scatter of the next).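

In this assay, placing acetyl on this amine nitrogen gives a 1.5-fold lower number from compound 2 to compound 3 (0.18 log units; within the scatter), so this nitrogen can carry an acyl group without a shift beyond the scatter. Exchanging the whole amino group on the saturated chain carbon gives a 1.0-fold higher number from compound 1 to compound 3 (0.00 log units; within the scatter), which also stays within the scatter. Nothing measured here accounts for these results.

From the compounds shown here alone, whether a longer acyl chain, such as butanoyl, or a benzoyl group on this nitrogen changes the number beyond the scatter stays open. So does the step for adding acetyl when a carboxylic acid replaces the ethyl ester.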